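Fluorine on the Core and Inhibition of Colon Cell Growth

The source may report more compounds than this note shows. Statements on the series, on what has been measured and on what is new or still open speak of the compounds shown alone.

compound 1, `O=C1C(=O)N(CCCCn2cc(COc3cc(=O)oc4ccccc34)nn2)c2ccccc21`: 68%
compound 2, `O=C1C(=O)N(CCCn2cc(COc3cc(=O)oc4ccccc34)nn2)c2ccccc21`: 75%
compound 3, `O=C1C(=O)N(CCCn2cc(COc3cc(=O)oc4ccccc34)nn2)c2ccc(F)cc21`: 69%

All three were measured in a functional assay on COLO 205 cells (Homo sapiens) for inhibition, read by sulforhodamine B assay, with a stated time of 48 h, tested at 50 uM; a lower number here means less inhibition of growth, a higher number more inhibition of growth at the concentration tested. Compound 2 and compound 3 share a core; the difference between the core of compound 1 and the core of compound 2 is not broken down here. Compound 3 differs from compound 2 by fluoro in place of hydrogen on an aromatic carbon, and this change gave a number 6 percentage points lower from compound 2 to compound 3 (within the scatter). Compound 4, `O=C1C(=O)N(CCCCn2cc(COc3cc(=O)oc4ccccc34)nn2)c2ccc(F)cc21`, carries the same change relative to compound 1: fluoro in place of hydrogen on an aromatic carbon. Because the earlier step of a number 6 percentage points lower from compound 2 to compound 3 (within the scatter) stayed within the scatter, a step of similar small size is expected for compound 4, namely a number 4 percentage points lower from compound 1 to compound 4 (within the scatter). Compound 4 is therefore estimated at 64% in this assay, with a likely range from 50% to 78%.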

Compound 4, percent growth inhibition at one concentration: 64%
The estimate for compound 4 equals the measured number at the digits printed; the range from low to high includes it.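

In this assay, fluoro in place of hydrogen on an aromatic carbon gave a number 4 percentage points lower from compound 1 to compound 4 (within the scatter). Set beside the earlier step, the same change looks alike on the two cores: the same change on two cores in this assay, a number 6 percentage points lower (within the scatter) from compound 2 to compound 3 and a number 4 percentage points lower (within the scatter) from compound 1 to compound 4, 2 percentage points apart, within the scatter of two such steps. This shows no sign that the core alters the outcome of this change, but with both steps within the scatter, it does not show that fluoro lowers growth inhibition on either core, and two pairs cannot speak for other cores.

The compounds shown leave open what a chloro, methoxy or amine group would do on the same aromatic carbon. They also leave open how fluoro would behave with a longer chain.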